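The compounds below may be only part of what the source reports. "The series", "measured", "known", "first", "only" and "open" are said of these compounds alone.

The measured compounds:
- compound 1, `COc1ccc(-c2cc(C(=O)/C=C/c3ccccc3)nc3cc(-c4ccccc4)nn23)cc1OC`, gives 15600 nM in a functional assay on DU-145 cells (Homo sapiens) for antiproliferative activity, read by MTT assay, with a stated time of 24 h; a lower number here means a stronger inhibitor, a higher number a weaker inhibitor
- compound 2, `COc1cc(C(=O)/C=C/c2cc(-c3cc(OC)c(OC)c(OC)c3)n3nc(-c4ccccc4)cc3n2)cc(OC)c1OC`, gives 34900 nM
- compound 3, `COc1ccc(-c2cc(/C=C/C(=O)c3cc(OC)c(OC)c(OC)c3)nc3cc(-c4ccccc4)nn23)cc1OC`, gives 8300 nM

Compound 1 stands second highest of the three numbers in this assay. Its gap to compound 3 lies within the usual scatter, while its gap to compound 2 lies beyond it. Among the measured compounds shown here, only one step between compounds that differ in a single place is known: a 4.2-fold lower number from compound 2 to compound 3 (0.62 log units; beyond the scatter).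

Compound 4, `COc1ccc(-c2cc(C(=O)/C=C/c3ccc(Cl)cc3)nc3cc(-c4ccccc4)nn23)cc1OC`, differs from compound 1 by chloro in place of hydrogen on an aromatic carbon. For the measured compounds named here, the one known step concerns the loss of a methoxy group on a different part of the molecule, not the gain of a chloro group, so it does not speak to this change. Going by the values given here, no measured step bears directly on adding a chloro group, and so no change beyond the scatter is expected in this assay for compound 4. The estimate for compound 4 is 12000 nM, with a range from 4500 nM to 32000 nM. The expected step is a 1.3-fold lower number from compound 1 to compound 4 (0.11 log units; within the scatter).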

Compound 4, half-maximal inhibitory concentration: 22400 nM
Estimate against measurement, compound 4: 1.9-fold (0.27 log units) below; low and high end bracket the measured number.
By their numbers in this assay, from the lowest: compounds 3, 1, 4 and 2 (each within the scatter of the next, the first and the last beyond it).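

Going from phenyl to 4-chlorophenyl at the end of the (2-phenylethenyl)carbonyl arm gives a small step in this assay (a 1.4-fold higher number from compound 1 to compound 4 (0.16 log units; within the scatter)). So a single chloro group at this carbon, on a six-membered aromatic ring of carbon only, leaves the number within the usual scatter of repeated measurements, which the earlier step on methoxy, on a different part of the molecule, could not show. Nothing measured here bears on what lies behind this result.

Going by these compounds, one chloro group is a single probe, so it remains open whether an amine, a hydroxyl group or a carboxylic acid on this same carbon would move the number beyond the scatter. On these data alone, it also remains open whether chloro would behave the same way on compound 3, which carries a different arm.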